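Ethoxy to Isopropoxy Across Two Related Acid Series

A few compounds are considered here, and "the series" means these few. Any claim that something is new, unique, unknown or untested is made for them only; others in the source may bear on it.

Compound 1 `CCOc1ccc(-c2cc(C(=O)O)nn2-c2ccc(Oc3ccccc3)cc2)cc1` and compound 2 `CC(C)Oc1ccc(-c2cc(C(=O)O)nn2-c2ccc(Oc3ccccc3)cc2)cc1` share one core and differ in a single spot: methyl in place of hydrogen on a saturated chain carbon bound to an oxygen on an aromatic ring and a saturated chain carbon. In an assay for displacement of a labelled ligand from E3 ubiquitin-protein ligase Mdm2 (Homo sapiens), read by fluorescence polarization, with a stated time of 30 min (on this read-out higher numbers stand for weaker inhibition and lower numbers for stronger inhibition), compound 1 gives 1030 nM, and compound 2 gives 712 nM. The step of a 1.4-fold lower number from compound 1 to compound 2 (0.16 log units; within the scatter) is small enough that the two numbers cannot be told apart with confidence.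

Compound 3 `CCOc1ccc(-c2c(NC(=O)c3ccc(OC(C)C)cc3)c(C(=O)O)nn2-c2ccc(Oc3ccccc3)cc2)cc1` has a larger core; the difference between the two cores is not broken down here. In this assay compound 3 gives 301 nM, the lowest of the three numbers, and its gaps to compound 1 and to compound 2 both lie beyond the scatter.

Compound 4 `CC(C)Oc1ccc(C(=O)Nc2c(C(=O)O)nn(-c3ccc(Oc4ccccc4)cc3)c2-c2ccc(OC(C)C)cc2)cc1` has not yet been measured. It differs from compound 3 by methyl in place of hydrogen on a saturated chain carbon bound to an oxygen on an aromatic ring and a saturated chain carbon, which is the same change as that between compound 1 and compound 2, at the same kind of place. The expectation for compound 4 rests on the earlier step of a 1.4-fold lower number from compound 1 to compound 2 (0.16 log units; within the scatter), which was small. Compound 4 is therefore expected to show a step of a 1.3-fold lower number from compound 3 to compound 4 (0.12 log units; within the scatter) in this assay. The estimate for compound 4 is 230 nM, most likely falling between 110 nM and 480 nM.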

Compound 4, inhibition constant: 107 nM
Estimate against measurement, compound 4: 2.1-fold (0.33 log units) above; measured number below the stated range.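

In this assay the change from ethoxy to isopropoxy on the larger core gives a 2.8-fold lower number from compound 3 to compound 4 (0.45 log units; beyond the scatter), so here, unlike on the smaller core, the step can be read as a real gain in inhibition. Going by these compounds alone, although only one of the two steps lies beyond the scatter, both lower the number, and their sizes cannot be told apart: the same change on two cores in this assay, a 1.4-fold lower number (0.16 log units; within the scatter) from compound 1 to compound 2 and a 2.8-fold lower number (0.45 log units; beyond the scatter) from compound 3 to compound 4, 1.9-fold (0.29 log units) apart, within the scatter of two such steps. This supports carrying the change from one core to the other as harmless and possibly helpful, but it does not show that the larger core strengthens the effect, and a single pair on each core cannot establish a rule for the whole series.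

The compounds shown leave open what a tert-butyl group or a longer chain, such as butyl, would do at this place on either core. They also leave open whether the change from ethoxy to isopropoxy would behave in the same way on a third core.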